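The compounds below may be only part of what the source reports. "The series", "measured", "known", "first", "only" and "open" are said of these compounds alone.

Compound 1 `CN1CCN(c2nc(N)nc(COc3ccccc3Cl)n2)CC1`: 129 nM
Compound 2 `CC(Oc1cccc(Cl)c1)c1nc(N)nc(N2CCN(C)CC2)n1`: 118 nM

Both compounds share the same core and were measured in an assay on HEK293 cells for displacement of a labelled ligand from 5-hydroxytryptamine receptor 6 (Homo sapiens), read by radioligand binding, with a stated time of 1 h; on this read-out lower numbers stand for stronger inhibition and higher numbers for weaker inhibition. In this assay compound 1 gives 129 nM, and compound 2 gives 118 nM. Compound 2 thus stands alongside compound 1: the two numbers fall within the usual scatter of one another, so nothing separates them on this read-out. Among the compounds with values here, compound 1 and compound 2 differ from each other in two places at once, and no single step between them can be read from their values; they simply show that both arrangements reach a similar number.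

The next compound, compound 3 `CC(Oc1ccccc1Cl)c1nc(N)nc(N2CCN(C)CC2)n1`, is built from compound 2 by one change: 2-chlorophenyl in place of 3-chlorophenyl on an oxygen on a saturated carbon. The two have the same atoms, joined differently. Compound 1 already carries the 2-chlorophenoxy arrangement on a plainer linker and gives 129 nM, which sits within the scatter of compound 2. On that basis the step is expected to stay within the scatter, with no clear direction.

Compound 3 is therefore estimated at 130 nM in this assay, with a range of 60 nM to 280 nM. The step this estimate implies is a 1.1-fold higher number from compound 2 to compound 3 (0.04 log units; within the scatter), expected to be small.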

Compound 3, inhibition constant: 23 nM
The estimate for compound 3 lay 5.7-fold (0.75 log units) above the measured number; the whole stated range lies above it.
By their numbers in this assay, from the lowest: compound 3; then compounds 2 and 1 (each within the scatter of the next).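

In this assay, within the data shown here, 2-chlorophenyl in place of 3-chlorophenyl on an oxygen on a saturated carbon gives a 5.1-fold lower number from compound 2 to compound 3 (0.71 log units; beyond the scatter), the first single change in this set that can be read, and it shows that where the chlorine sits on the phenyl ring matters once the methyl is on the linker. The second step, methyl in place of hydrogen on a saturated chain carbon bound to an aromatic carbon and an oxygen on an aromatic ring, gives a 5.6-fold lower number from compound 1 to compound 3 (0.75 log units; beyond the scatter), so with the 2-chlorophenoxy group held fixed, this methyl also matters. Compound 3 carries both features and has a lower number than either neighbour, which the near-equal values of the earlier pair could not have revealed, since those two compounds differ in two places at once.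

As far as these compounds go, how the 3-chlorophenoxy group behaves on the plainer linker stays open, as does whether a 2-fluorophenyl or 2-methoxyphenyl group, or an ethyl on the linker carbon, would keep the number this low. Nothing available here accounts for either step.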